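The source may report more compounds than this note shows. Statements on the series, on what has been measured and on what is new or still open speak of the compounds shown alone.

Three compounds have so far been measured in an ADME assay on RD cells (Homo sapiens) for cytotoxicity, read by MTT assay, with a stated time of 3 days; on this read-out higher numbers stand for lower toxicity in this test and lower numbers for higher toxicity in this test:

Compound 1 `CCCC[C@@H](CCn1cncn1)c1ccccc1`: 47.5 ug/mL
Compound 2 `CCCC[C@@H](CCn1cncn1)c1ccc(Cl)cc1`: 18.7 ug/mL
Compound 3 `CCCC[C@H](CCn1cncn1)c1ccc(F)cc1`: 35.2 ug/mL

Compound 3 is the point of departure. In this assay compound 3 gives 35.2 ug/mL, and its gap to compound 1 and its gap to compound 2 both lie within the usual scatter, so no order among the three can be read from it. Among the compounds with values here, the only step that is resolved runs a 2.5-fold lower number from compound 1 to compound 2 (0.40 log units; beyond the scatter).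

Compound 4 `CCCC[C@@H](CCn1cncn1)c1ccc(F)cc1` is the next compound. Its relation to compound 3 is the two compounds have the same atoms and bonds and differ only in configuration as drawn: 1 of 1 stereo elements differ; a stereocentre at a saturated chain carbon is drawn R in compound 3 and S in compound 4. Within the data shown here, the one resolved step concerns a chloro in place of hydrogen on an aromatic carbon and says nothing about configuration; no measured pair differs only in the drawn stereocentre. With nothing to anchor a direction, the step is expected to be a 1.0-fold lower number from compound 3 to compound 4 (0.00 log units; within the scatter), that is, none beyond the scatter. Compound 4 is therefore estimated at 35 ug/mL, with a range from 17 ug/mL to 70 ug/mL.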

Compound 4, half-maximal cytotoxic concentration: 34.1 ug/mL
Compound 4: the middle estimate sits 1.0-fold (0.01 log units) above what was measured; the measured number falls inside the stated range.
By their numbers in this assay, from the lowest: compounds 2, 4, 3 and 1 (each within the scatter of the next, the first and the last beyond it).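

In this assay, the drawn stereocentre at the saturated chain carbon now has a measured pair, and it gives a 1.0-fold lower number from compound 3 to compound 4 (0.01 log units; within the scatter), so the two drawn configurations are not separated for this fluoro compound: the fact that compounds 3 and 4 differ only in the configuration as drawn. On the aromatic carbon, the exchange of chloro for fluoro gives a 1.8-fold higher number from compound 2 to compound 4 (0.26 log units; within the scatter), and the exchange of hydrogen for fluoro gives a 1.4-fold lower number from compound 1 to compound 4 (0.14 log units; within the scatter). Fluoro therefore cannot be told apart from either chloro or hydrogen here, even though those two are resolved from each other by a 2.5-fold lower number from compound 1 to compound 2 (0.40 log units; beyond the scatter).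

As far as these compounds go, whether configuration is equally silent with chloro or hydrogen on the aromatic carbon remains open. From the compounds shown here alone, it is also open how an amine or a methoxy group at that carbon, or a longer chain on the stereocentre, would read in this assay.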